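The source may report more compounds than this note shows. Statements on the series, on what has been measured and on what is new or still open speak of the compounds shown alone.

Working notes on the series.

Of the compounds shown here, two have been measured in a functional assay (cardiac atrium) for agonist activity, with Cavia porcellus as the target; a higher number here means that more compound is needed for the effect, a lower number that less compound is needed. Compound 1 `CC1=C(C(=O)OCCCCO[N+](=O)[O-])C(c2cccc3nonc23)C([N+](=O)[O-])=C(C)C1` gives 4030 nM in this assay. Compound 2 `CC1=C(C(=O)O[C@@H](C)CO[N+](=O)[O-])[C@H](c2cccc3nonc23)C([N+](=O)[O-])=C(C)C1`, which carries a different ester and is a single stereoisomer, gives 156 nM in this assay. Compound 1 thus stands at the highest of the two numbers, and the gap between it and compound 2 is beyond the scatter of repeated measurements.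

Compound 3 `CC1=C(C(=O)OCC(C)O[N+](=O)[O-])C(c2cccc3nonc23)C([N+](=O)[O-])=C(C)C1` is the next member and has not yet been measured. It differs from compound 1 in one place: 1-(nitrooxy)ethyl in place of 3-(nitrooxy)propyl on a saturated chain carbon bound to an oxygen next to a carbonyl group. No step between two measured compounds isolates this change, so the expectation rests on compound 1 and on the direction shown by compound 2 alone. The step from compound 1 to compound 3 is expected to be a moderate decrease in the number, a 3.4-fold lower number from compound 1 to compound 3 (0.53 log units; beyond the scatter), with wide uncertainty. For compound 3 the estimate in this assay is 1200 nM, within a range of 350 nM to 4000 nM.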

Compound 3, half-maximal effective concentration: 972 nM
The estimate for compound 3 lay 1.2-fold (0.09 log units) above the measured number; low and high end bracket the measured number.
By their numbers in this assay, from the lowest: compound 2; then compound 3; then compound 1.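

In this assay, the ester chain on the shared core now gives its first readable single change: a 4.1-fold lower number from compound 1 to compound 3 (0.62 log units; beyond the scatter), with 1-(nitrooxy)ethyl in place of 3-(nitrooxy)propyl on a saturated chain carbon bound to an oxygen next to a carbonyl group. This step lies beyond the scatter, so the number responds to a change at this position even though both groups keep the nitrooxy function. Nothing at hand bears on the reason for this shift.

This one step cannot separate the shorter chain from the different attachment of the nitrooxy group along it. Also open, on these data alone, are how a plain ethyl ester with no nitrooxy group, or a longer chain carrying that group, would behave at this position.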